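Moving a Chlorine Around the Ring on a Receptor Ligand

The compounds below may be only part of what the source reports. "The series", "measured", "known", "first", "only" and "open" are said of these compounds alone.

compound 1 `CC(=O)Nc1cccc(C2CCN(CCCn3c(-c4ccc(Br)cc4)nc4ccccc43)CC2)c1`: 5 nM
compound 2 `CC(=O)Nc1cccc(C2CCN(CCCn3c(-c4ccc(Cl)cc4Cl)nc4ccccc43)CC2)c1`: 3 nM

In an assay for displacement of a labelled ligand from melanin-concentrating hormone receptor 1 (Homo sapiens), read by fluorescence (on this read-out lower numbers stand for stronger inhibition and higher numbers for weaker inhibition), compound 1 gives 5 nM and compound 2 gives 3 nM. Among the compounds with values here, the two sit within the usual scatter of each other, the only measured step being a 1.7-fold lower number from compound 1 to compound 2 (0.22 log units; within the scatter). Compound 3 `CC(=O)Nc1cccc(C2CCN(CCCn3c(-c4ccc(Cl)c(Cl)c4)nc4ccccc43)CC2)c1` differs from compound 2 by 3,4-dichlorophenyl in place of 2,4-dichlorophenyl on an aromatic carbon. Within the data shown here, the one step that bears on it, an exchange of one halogenated ring for another, stayed within the scatter, so no step beyond the scatter is expected in this assay: a 1.3-fold higher number from compound 2 to compound 3 (0.12 log units; within the scatter). Compound 3 is therefore estimated at 4 nM, within a range of 1.3 nM to 12 nM.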

Compound 3, half-maximal inhibitory concentration: 24 nM
Compound 3: middle estimate off by 6.0-fold (0.78 log units), on the low side; measured number above the stated range.
By their numbers in this assay, from the lowest: compounds 2 and 1 (each within the scatter of the next); then compound 3.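

In this assay the position on the aromatic carbon between two ring nitrogen atoms proved sensitive to the placement of chlorine on the ring it carries: the change to 3,4-dichlorophenyl gave an 8.0-fold higher number from compound 2 to compound 3 (0.90 log units; beyond the scatter) with the atom count unchanged. Against 4-bromophenyl the same group gave a 4.8-fold higher number from compound 1 to compound 3 (0.68 log units; beyond the scatter) and so also stood apart, while the earlier exchange of halogenated rings had stayed within the scatter. Nothing available accounts for this difference. The compounds shown leave open whether a single chlorine on the ring, as in 2-chlorophenyl or 3-chlorophenyl, would behave like either dichlorophenyl group. They also leave open how a ring carrying methoxy or an amine would fare here.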